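The source may hold more compounds than are shown below. What is called first, only, known or untested is meant among the compounds shown, and "the series" means these compounds.

Working notes on the acyl-chain series. Compound 1 `CCCCCCCCCCCC(=O)N[C@@H](CO)C[C@@H](O)c1ccccc1` gives 70 nM in a functional assay on CHO cells (Cricetulus griseus) for inhibition; on this read-out lower numbers stand for stronger inhibition and higher numbers for weaker inhibition. Compound 2 `CCCCCCCCCCCCCCC(=O)N[C@@H](CO)C[C@@H](O)c1ccccc1` gives 90 nM in this assay, and compound 3 `CCCCCCCCCCCCC(=O)N[C@@H](CO)C[C@@H](O)c1ccccc1` gives 50 nM. Compound 4 `CCCCCCCCCC(=O)N[C@@H](CO)C[C@@H](O)c1ccccc1` is not yet measured.

Between compound 2 and compound 1 the change is hydrogen in place of propyl on a saturated chain carbon, ten or more bonds along the chain from a carbonyl carbon; it produced a 1.3-fold lower number from compound 2 to compound 1 (0.11 log units; within the scatter). The same kind of change, not the same one, separates compound 3 from compound 4: hydrogen in place of propyl on a saturated chain carbon, nine bonds along the chain from a carbonyl carbon. The two cores differ by hydrogen in place of ethyl on a saturated chain carbon, ten or more bonds along the chain from a carbonyl carbon, which moves the place of the change one bond closer to the carbonyl carbon; that step read a 1.8-fold lower number from compound 2 to compound 3 (0.26 log units; within the scatter).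

Among the compounds with values here, for compound 4 the expected step is a 1.2-fold higher number from compound 3 to compound 4 (0.08 log units; within the scatter), resting on a 1.3-fold lower number from compound 2 to compound 1 (0.11 log units; within the scatter) and on every step so far lying within the scatter. Compound 4 is therefore estimated at 60 nM, between 30 nM and 130 nM.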

Compound 4, half-maximal inhibitory concentration: 300 nM
The estimate for compound 4 lay 5.0-fold (0.70 log units) below the measured number; the measured number lies above the stated range.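

Hydrogen in place of propyl, nine bonds along the chain from a carbonyl carbon, gives a 6.0-fold higher number from compound 3 to compound 4 (0.78 log units; beyond the scatter) in this assay, so this change does not carry over unchanged from the core of compound 2 to the core of compound 3: the same change on two cores in this assay, a 1.3-fold lower number (0.11 log units; within the scatter) from compound 2 to compound 1 and a 6.0-fold higher number (0.78 log units; beyond the scatter) from compound 3 to compound 4, 7.7-fold (0.89 log units) apart, beyond the scatter of two such steps. Hydrogen in place of ethyl on compound 1 gives a 4.3-fold higher number from compound 1 to compound 4 (0.63 log units; beyond the scatter), and hydrogen in place of pentyl gives a 3.3-fold higher number from compound 2 to compound 4 (0.52 log units; beyond the scatter), so the ethyl change does not carry over either: the same change on two cores in this assay, a 1.8-fold lower number (0.26 log units; within the scatter) from compound 2 to compound 3 and a 4.3-fold higher number (0.63 log units; beyond the scatter) from compound 1 to compound 4, 7.7-fold (0.89 log units) apart, beyond the scatter of two such steps. The size of the step thus depends on the core it is made on, but compound 4 alone does not show why, or whether the same holds for other chains.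

Still open, as far as these compounds go, is how a shorter chain than that of compound 4, or a longer chain than that of compound 2, would read. Also open, from the compounds shown here alone, is whether a chain ending in an amine or a carboxylic acid would read closer to compound 4 or to compound 3.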